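This account rests on a few compounds, and the source may have more. Where it says the series, first, only, none or still open, it means among the compounds named here.

Measured so far:
- compound 1 `CC1=CC[C@H](C(C)(C)NC(=S)N/N=C/c2ccccc2)CC1` — in a functional assay on MCF7 cells (Homo sapiens) for inhibition, read by sulforhodamine B assay, with a stated time of 48 h (a lower number here means a stronger inhibitor of growth, a higher number a weaker inhibitor of growth), compound 1 gives 8400 nM
- compound 2 `CC1=CC[C@H](C(C)(C)NC(=S)N/N=C/c2ccc(O)cc2)CC1` — in this assay compound 2 gives only a limit, > 100000 nM

Compound 2 stands at the weak end of the two values shown. Its entry is not a number but a limit, (the limit of > 100000 nM in this assay, at which 1 of the 2 values shown sits), so the true position of compound 2 is known only as lying beyond that point. Within the data shown here, the one measured step on this pair, an at least 11-fold higher number from compound 1 to compound 2 (1.07 log units; beyond the scatter), is large and beyond the scatter.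

Compound 3 `CC1=CC[C@H](C(C)(C)NC(=S)N/N=C/c2ccc(N(C)C)cc2)CC1` is the next member. It differs from compound 2 by dimethylamino in place of hydroxy on an aromatic carbon. Among the measured compounds shown here, no measured step covers this change directly; the only step available is the one from compound 1 to compound 2, which removed a hydrogen in favour of hydroxy at the same position and cost a large amount. Compound 3 takes that hydroxy away again and puts dimethylamino in its place, so the outcome can be framed only between the limit of compound 2 and the value of compound 1. The expected step is an at least 2.5-fold lower number from compound 2 to compound 3 (0.39 log units; beyond the scatter). For compound 3 the estimate in this assay is 40000 nM, within 6000 nM to 150000 nM.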

Compound 3, concentration for 50% growth inhibition: 26800 nM
The estimate for compound 3 lay 1.5-fold (0.17 log units) above the measured number; the measured number falls inside the stated range.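

On the six-membered aromatic ring of carbon only, para to a large group, the loss seen with hydroxy does not apply to every group placed there: in this assay, dimethylamino in place of hydroxy gives an at least 3.7-fold lower number from compound 2 to compound 3 (0.57 log units; beyond the scatter). This recovery is incomplete, as dimethylamino in place of hydrogen gives a 3.2-fold higher number from compound 1 to compound 3 (0.50 log units; beyond the scatter), so both substituents shown here give a higher number than hydrogen, but by different amounts. Compound 2 is a limit and not a number, so the first of these steps has no upper end: the limit of > 100000 nM in this assay, at which 1 of the 3 values shown sits.

The compounds shown leave open which part of the change from hydroxy to dimethylamino matters, since the two groups differ at once in heavy atoms and in hydrogen-bond donors. A methoxy group or a primary amine at the same place would help to separate these two differences, while a chlorine atom there would test whether a substituent without oxygen or nitrogen can match the value of compound 1.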